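This account rests on a few compounds, and the source may have more. Where it says the series, first, only, none or still open, it means among the compounds named here.

Values in an ADME assay on microsomes from liver (Homo sapiens) for metabolic stability, read by LC-MS, with a stated time of 30 min, tested at 1 uM; on this read-out lower numbers stand for a less stable compound and higher numbers for a more stable compound:
- compound 1 `Cc1ccccc1S(=O)(=O)c1ccc(CNC(=O)c2cc3cnccc3[nH]2)cc1`: 48%
- compound 2 `O=C(NCc1ccc(S(=O)(=O)c2ccccc2C(F)(F)F)cc1)c1cc2cnccc2[nH]1`: 52%
- compound 3 `O=C(NCc1ccc(S(=O)(=O)c2ccc(F)c(F)c2)cc1)c1cc2cnccc2[nH]1`: 100%

Compound 3 stands highest of the three in this assay. The gaps to it are large and beyond the scatter: a number 52 percentage points higher from compound 1 to compound 3 (beyond the scatter) and a number 48 percentage points higher from compound 2 to compound 3 (beyond the scatter). By contrast, a number 4 percentage points higher from compound 1 to compound 2 (within the scatter) lies within the scatter.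

Compound 4 `O=C(NCc1ccc(S(=O)(=O)c2ccc(F)cc2)cc1)c1cc2cnccc2[nH]1` is the next case, and its change from compound 3 is hydrogen in place of fluoro on an aromatic carbon. Within the data shown here, the two large steps each exchange a whole aryl group on the sulfonyl sulfur, so no measured step shows this single change alone. They show only that this position in the series can move the read-out strongly. Compound 4 keeps one fluoro, so a moderate fall is expected rather than a full loss of the gap.

The expected change is a number 18 percentage points lower from compound 3 to compound 4 (beyond the scatter), though this estimate is uncertain. For compound 4 the estimated value is 82%, with an expected range from 60% to 100%.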

Compound 4, percent of the compound remaining: 91%
Compound 4: the middle estimate sits 9 percentage points below what was measured; measured number inside the range.
By their numbers in this assay, from the lowest: compounds 1 and 2 (each within the scatter of the next); then compounds 4 and 3 (each within the scatter of the next).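

With a number 9 percentage points lower from compound 3 to compound 4 (within the scatter) in this assay, hydrogen in place of fluoro on this aromatic carbon gives a step that cannot be told from the scatter, so the 3,4-difluorophenyl and 4-fluorophenyl groups read alike here. The 4-fluorophenyl group still stands well apart from the two other aryl groups on the sulfonyl sulfur, with a number 39 percentage points higher from compound 2 to compound 4 (beyond the scatter) and a number 43 percentage points higher from compound 1 to compound 4 (beyond the scatter) as large steps. Among these four compounds, the large gaps to compound 1 and compound 2 therefore do not depend on the second fluoro.

Open, going by these compounds, is how this ring would read with no fluoro at all, or with an amine, a carboxylic acid or a nitrile in place of the remaining fluoro. Also open is what lies behind these steps, since no measurement on that is at hand.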